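The source may hold more compounds than are shown below. What is called first, only, known or untested is meant among the compounds shown, and "the series" means these compounds.

Two compounds have been measured so far in a functional assay on L1210 cells (Mus musculus) for antiproliferative activity; on this read-out higher numbers stand for higher potency (the scale is a negative logarithm) and lower numbers for lower potency:

compound 1, `CCCCN(C)/N=N/c1n[nH]cc1C(=O)OCC`, gives 3.16
compound 2, `CCCN(C)/N=N/c1nc[nH]c1C(N)=O`, gives 3.58

Compound 1 stands lowest of the two numbers; compound 2 sits higher in this assay, and that gap lies beyond the usual scatter of repeated measurements. Among the compounds with values here, no pair of measured compounds differing in a single place is available, so no measured step can guide the next move directly.

Compound 3, `CCOC(=O)c1c[nH]nc1/N=N/N(C)C`, has not yet been measured in this assay. It differs from compound 1 in one place: hydrogen in place of propyl on a saturated chain carbon bound to an amine nitrogen. Put another way, the butyl(methyl)amino group of compound 1 becomes a dimethylamino group, so compound 3 is the shorter-chained relative.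

Within the data shown here, with nothing among the measured compounds to show what shortening this chain does, the expectation rests on the change itself: a modest shift in this assay, most likely a small loss or none beyond the scatter. For compound 3 the expected value in this assay is 3, with a plausible range from 2.4 to 3.6, which corresponds to an expected step of a number 0.16 log units lower from compound 1 to compound 3 (within the scatter).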

Compound 3, logarithm of the reciprocal of the active concentration, log(1/C): 3.35
The estimate for compound 3 lay 0.35 log units below the measured number; low and high end bracket the measured number.
By their numbers in this assay, from the lowest: compounds 1, 3 and 2 (each within the scatter of the next, the first and the last beyond it).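

Within the data shown here, this is the first change in a single place that can be read in this assay: putting hydrogen in place of propyl on a saturated chain carbon bound to an amine nitrogen, which turns butyl(methyl)amino into dimethylamino, gives a number 0.19 log units higher from compound 1 to compound 3 (within the scatter) and so no change that can be told apart from the noise of repeat measurements. For this one pair, then, the chain at this position can be cut from butyl to methyl with the read-out holding within that scatter, which the two earlier compounds alone could not show because they differ in more than one place. Nothing measured on these compounds speaks to why the two read alike.

From the compounds shown here alone, whether a longer chain such as hexyl, or a propyl chain ending in an amine or a carboxylic acid, would also read alike at this position in this assay remains open. Also open, going by these compounds, is whether the same shortening would behave the same way on the core of compound 2, since a single pair cannot show how far this result carries to other compounds.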